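This account rests on a few compounds, and the source may have more. Where it says the series, first, only, none or still open, it means among the compounds named here.

Measured compounds:
Compound 1 `COC(=O)Cn1nc2c(n1)C(=O)C(C)=C(C)C2=O` gives 4 ug/mL in a functional assay on KB cells (Homo sapiens) for inhibition, read by colorimetric assay, with a stated time of 72 h; on this read-out lower numbers stand for an effect already at smaller amounts and higher numbers for an effect only at larger amounts of compound.
Compound 3 `CC1=CC(=O)c2nn(C)nc2C1=O` gives 2.5 ug/mL in this assay.
Compound 2 `COC(=O)C(C)n1n[n+]([O-])c2cc(C)c(C)cc21` reaches only a limit of the assay, > 100 ug/mL in this assay.

Compound 1 and compound 3 share a core, and the two values stand within the usual scatter of each other. Compound 2 has a different core, and for compound 2 the read-out is only a limit, not a number, which is the situation described by the limit of > 100 ug/mL in this assay, at which 1 of the 3 values shown sits. Where compound 2 stands within the measured set is therefore known only as a limit.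

Compound 4 `COC(=O)Cn1n[n+]([O-])c2cc(C)c(C)cc21` is not yet measured. It differs from compound 2 by hydrogen in place of methyl on a saturated chain carbon bound to an aromatic nitrogen and a carbonyl carbon. Among the measured compounds shown here, no pair of measured compounds differs in one place, so the size of such a step has to be judged without a measured example. Since compound 2 shows only > 100 ug/mL, and the change is a single small group on the side chain, the step of a number no higher from compound 2 to compound 4 (the limit leaves the size open) is expected to be none beyond the scatter, and compound 4 is expected most likely to return a limit again. The estimate for compound 4 is 100 ug/mL, within the range 30 ug/mL to 300 ug/mL.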

Compound 4, concentration for half-maximal effect: > 100 ug/mL
Compound 4 gave a limit, no number; the forecaster's own chance of this, stated with the estimate: 75%; the middle value sits exactly at the limit.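

Compound 2 and compound 4 both stop at a limit of the assay rather than a number, so no size can be read for the change from methyl to hydrogen: the limit of > 100 ug/mL in this assay, at which 2 of the 4 values shown sit. The compounds shown leave open whether this change has any effect in this assay on a compound that returns a number.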